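Benzotriazine di-N-oxide amines: cytotoxicity in PC-3 cells

This account rests on a few compounds, and the source may have more. Where it says the series, first, only, none or still open, it means among the compounds named here.

Measured so far:
Compound 1 `CCCOCNc1n[n+]([O-])c2cc(OC)ccc2[n+]1[O-]` gives 10600 nM
Compound 2 `[O-][n+]1nc(NCOCc2ccc(C(F)(F)F)cc2)[n+]([O-])c2ccccc21` gives 9310 nM

In a functional assay on PC-3 cells (Homo sapiens) for cytotoxicity, read by MTT assay, with a stated time of 72 h (a lower number here means a stronger inhibitor, a higher number a weaker inhibitor), compound 1 gives 10600 nM. In this assay compound 2 gives 9310 nM. The two numbers sit within the scatter of each other, so the values of compound 1 and compound 2 show no difference that can be read as real; both sit in the same weak range. Among the compounds with values here, no step between measured compounds is available for the change considered next.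

Compound 3 `[O-][n+]1nc(NCOCc2ccc(Cl)cc2)[n+]([O-])c2ccccc21` is not yet measured in this assay. It differs from compound 2 by chloro in place of trifluoromethyl on an aromatic carbon. Within the data shown here, with only two measured compounds, both weak and indistinguishable from each other, there is no basis in the data for expecting the exchange to move the number beyond the scatter in either direction. For compound 3 the estimate is 9000 nM, between 3000 nM and 27000 nM, which means an expected step of a 1.0-fold lower number from compound 2 to compound 3 (0.01 log units; within the scatter).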

Compound 3, half-maximal inhibitory concentration: 5100 nM
The estimate for compound 3 lay 1.8-fold (0.25 log units) above the measured number; the measured number falls inside the stated range.
By their numbers in this assay, from the lowest: compounds 3, 2 and 1 (each within the scatter of the next, the first and the last beyond it).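

Chloro in place of trifluoromethyl on this aromatic carbon, para to a large group, gives the first readable step at this position in this assay: a 1.8-fold lower number from compound 2 to compound 3 (0.26 log units; within the scatter). The position therefore accepts either group without a difference that can be read as real, and this pair does not rank the two groups. Nothing measured here bears on a cause for the step.

From the compounds shown here alone, it remains open whether any other group on this aromatic carbon, such as an amine, a carboxylic acid or a nitrile, would separate from chloro and trifluoromethyl by more than the scatter. Going by these compounds, it also remains open whether the same exchange would read alike on the core of compound 1.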